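Shifting the group on the double-bonded nitrogen

This account rests on a few compounds, and the source may have more. Where it says the series, first, only, none or still open, it means among the compounds named here.

Compound 1 `N#CN/C(=N\c1ccccc1)Nc1cccnc1`: 5 mg/kg
Compound 2 `CCC(CC)/N=C(\NC#N)Nc1ccncc1`: 2.5 mg/kg
Compound 3 `CCC(C)(C)/N=C(\NC#N)Nc1ccncc1`: 2.5 mg/kg

In a functional assay on the whole organism (blood, strain Wistar-Okamoto) with Rattus norvegicus as the target, with a stated time of 5 days (on this read-out higher numbers stand for an effect only at larger amounts of compound and lower numbers for an effect already at smaller amounts), compound 3 gives 2.5 mg/kg, level with compound 2 and, with it, the lowest of the three numbers; compound 1 sits only within the scatter of it. Among the measured compounds shown here, the single measured step, no change at the digits printed from compound 2 to compound 3 (within the scatter), swapped one alkyl group for another and stayed within the scatter. Compound 4 `N#CN/C(=N\c1ccccc1)Nc1ccncc1` differs from compound 3 by phenyl in place of 1,1-dimethylpropyl on a double-bonded nitrogen. For the measured compounds named here, no measured step covers an alkyl-to-phenyl exchange at this position; the only phenyl-bearing compound, compound 1, lies near compounds 2 and 3. The estimated step of a 1.6-fold higher number from compound 3 to compound 4 (0.20 log units; within the scatter) is therefore expected to stay within the scatter. Compound 4 is expected to give about 4 mg/kg, in the range 2 mg/kg to 10 mg/kg.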

Compound 4, minimum effective dose: 50 mg/kg
Beside the measured number, compound 4's estimate is 13-fold (1.10 log units) below it, and the stated range ends below it.
By their numbers in this assay, from the lowest: compounds 2, 3 and 1 (each within the scatter of the next); then compound 4.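

In this assay the group on the double-bonded nitrogen proves to matter with pyridin-4-yl on the amine nitrogen: phenyl in place of either alkyl group gives a 20-fold higher number from compound 3 to compound 4 (1.30 log units; beyond the scatter) and a 20-fold higher number from compound 2 to compound 4 (1.30 log units; beyond the scatter). With phenyl kept, pyridin-4-yl in place of pyridin-3-yl on the amine nitrogen gives a 10-fold higher number from compound 1 to compound 4 (1.00 log units; beyond the scatter), so phenyl does not bring a high number in every compound shown. Nothing available explains this result. As far as these compounds go, it remains open whether cyclohexyl or benzyl on the double-bonded nitrogen would side with compound 3 or compound 4, and how pyridin-2-yl on the amine nitrogen would read.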